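A few compounds are considered here, and "the series" means these few. Any claim that something is new, unique, unknown or untested is made for them only; others in the source may bear on it.

Working notes on the series. Of the compounds shown here, three have so far been read in a functional assay on CHO cells for agonist activity at Free fatty acid receptor 1 (Homo sapiens), read by FLIPR and calcium flux; a higher number here means that more compound is needed for the effect, a lower number that less compound is needed. Compound 1 `CCOc1cc(C)c(-c2cccc(CNc3ccc(OCC(=O)O)cc3)c2)c(C)c1` gives 197 nM in this assay. Compound 2 `Cc1cc(OCCCS(C)(=O)=O)cc(C)c1-c1cccc(CNc2ccc(OCC(=O)O)c(F)c2)c1` gives 59.8 nM in this assay. Compound 3 `Cc1ccccc1-c1cccc(CNc2ccc(OCC(=O)O)c(F)c2)c1` gives 4.8 nM in this assay, the lowest of the three numbers; the gap to compound 2 is the nearest one and lies beyond the scatter, and the gap to compound 1 is the widest, also beyond the scatter. On the numbers shown, compound 3 thus stands clearly apart from the other two.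

Compound 4 `Cc1ccc(-c2cccc(CNc3ccc(OCC(=O)O)c(F)c3)c2)c(Cl)c1` has not been measured. It differs from compound 3 in one place: 2-chloro-4-methylphenyl in place of 2-methylphenyl on an aromatic carbon. Going by the values given here, no pair of measured compounds differs in only this kind of change, so no measured step speaks to it directly. Compounds 1 and 2 carry more heavily substituted rings at this same place than compound 3 and show higher numbers, but each also differs from compound 3 elsewhere, so this is only a loose hint. A small shift toward a somewhat higher number is expected, possibly not beyond the scatter, so the step from compound 3 to compound 4 is estimated at a 1.7-fold higher number from compound 3 to compound 4 (0.22 log units; within the scatter). Compound 4 is accordingly expected to give about 8 nM in this assay, within a range from 2.5 nM to 25 nM.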

Compound 4, half-maximal effective concentration: 22.5 nM
Estimate against measurement, compound 4: 2.8-fold (0.45 log units) below; measured number inside the range.
By their numbers in this assay, from the lowest: compound 3; then compound 4; then compound 2; then compound 1.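

Going by these compounds alone, this is the first step where only the phenyl group on this aromatic carbon changes, and in this assay it gives a 4.7-fold higher number from compound 3 to compound 4 (0.67 log units; beyond the scatter). Within the data shown here, the position therefore responds on its own to a change in this ring, which the earlier compounds could not show, since each of them also differed from compound 3 elsewhere; however, 2-chloro-4-methylphenyl differs from 2-methylphenyl in two features at once, a chlorine and an additional methyl, and this single step does not separate them. No measured data bear on the reason for this shift.

Still open, from the compounds shown here alone, is how much of the step belongs to each feature, which 2-chlorophenyl and 2,4-dimethylphenyl at the same place would help to separate, and how a methoxy group or a nitrile on this ring would read. Also open, going by these compounds, is whether the same exchange gives a step of similar size on the core of compound 1, where the remainder of the molecule is different.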